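The source may hold more compounds than are shown below. What is called first, only, known or untested is meant among the compounds shown, and "the series" means these compounds.

Three compounds of this series have numbers in a functional assay on U2OS cells (Homo sapiens) for antiproliferative activity, read by MTT assay, with a stated time of 72 h; on this read-out lower numbers stand for stronger inhibition and higher numbers for weaker inhibition. Compound 1 `Nc1ccc(SCC(=O)Nc2ccc3nc(NC(=O)c4ccc(C(F)(F)F)cc4)sc3c2)cc1` gives 1220 nM and stands lowest of the three. Compound 2 `CCCC(=O)Nc1nc2ccc(NC(=O)CSc3cccc(O)c3)cc2s1` gives 10100 nM, and compound 3 `Cc1ccc(S(=O)(=O)Nc2nc(C)c(NC(=O)Nc3ccc(Cl)cc3)s2)cc1` gives 88800 nM; both of these numbers lie beyond the usual scatter from that of compound 1, so compound 1 is the strongest of the three on this read-out, with compound 2 nearest and compound 3 furthest. Compound 4 `O=C(CSc1ncccc1C(=O)O)Nc1ccc2nc(NC(=O)c3ccc(C(F)(F)F)cc3)sc2c1` keeps the core of compound 1 and differs from it in one place only: 3-carboxypyridin-2-yl in place of 4-aminophenyl on a sulfur. Going by the values given here, no measured pair in the set carries this kind of change, so there is no step to lean on, and the expectation rests on the number of compound 1 alone. The step from compound 1 to compound 4 is expected to be modest and to run toward a weaker number, estimated as a 1.8-fold higher number from compound 1 to compound 4 (0.26 log units; within the scatter). For compound 4 in this assay the estimate is 2200 nM, with a range from 600 nM to 8000 nM.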

Compound 4, half-maximal inhibitory concentration: 13600 nM
For compound 4 the middle estimate is 6.2-fold (0.79 log units) below the measured one; measured number above the stated range.
By their numbers in this assay, from the lowest: compound 1; then compounds 2 and 4 (each within the scatter of the next); then compound 3.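

Within this assay, 3-carboxypyridin-2-yl in place of 4-aminophenyl on a sulfur gives an 11-fold higher number from compound 1 to compound 4 (1.05 log units; beyond the scatter), the first comparison in this set that isolates a single place. The group on this sulfur therefore matters to the read-out: this one exchange, with the rest of the structure unchanged, moves the number beyond the usual scatter, in favour of 4-aminophenyl. No measurement at hand bears on what lies behind this step.

The exchange alters the ring and its substituents together, so a single step cannot assign the loss to the ring nitrogen, the carboxylic acid or the absence of the amine. A plain phenyl ring, or a pyridine ring without the carboxylic acid, on the same sulfur would help separate these contributions.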